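Metabolic stability notes: piperazine sulfonamide carbinol series

The source may hold more compounds than are shown below. What is called first, only, known or untested is meant among the compounds shown, and "the series" means these compounds.

Measured so far:
compound 1 `CC#CCC(O)(c1ccc(N2CCN(S(=O)(=O)c3ccc(N)nc3)C[C@@H]2C#CC)cc1)C(F)(F)F` — 115 mL.min-1.g-1
compound 2 `CC#C[C@H]1CN(S(=O)(=O)c2ccc(N)nc2)CCN1c1ncc(C(O)(C(F)(F)F)C(F)(F)F)s1` — 34 mL.min-1.g-1
compound 3 `CC#C[C@H]1CN(S(=O)(=O)c2ccc(N)nc2)CCN1c1ccc(C(C)(O)C(F)(F)F)nc1` — 31 mL.min-1.g-1

In an ADME assay (liver) for metabolic stability, with Liver microsome (Rattus norvegicus) as the target, using microsomes and NADPH, with a stated time of 30 min (on this read-out higher numbers stand for fast clearance and lower numbers for slow clearance), compound 1 gives 115 mL.min-1.g-1, the highest of the three numbers; compound 2 at 34 mL.min-1.g-1 and compound 3 at 31 mL.min-1.g-1 both lie beyond the scatter below it. Compound 4 `CC#C[C@H]1CN(S(=O)(=O)c2ccc(N)nc2)CCN1c1ccc([C@](O)(CO)C(F)(F)F)cc1` is not yet measured. It differs from compound 1 on an aromatic carbon of the shared core: a group of 8 heavy atoms (3 carbon, 2 oxygen, 3 fluorine; no ring) in place of a group of 10 heavy atoms (6 carbon, 1 oxygen, 3 fluorine; no ring), on an aromatic carbon. The entering group carries two hydrogen-bond donors and no triple bond, against one donor and one triple bond in the leaving group. With no single-change step shown between any pair, the direction for a 2.9-fold lower number from compound 1 to compound 4 (0.46 log units; beyond the scatter) is expected to be downward in this assay, toward the numbers of compounds 2 and 3. Compound 4 is therefore estimated at 40 mL.min-1.g-1, within 15 mL.min-1.g-1 to 100 mL.min-1.g-1.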

Compound 4, intrinsic clearance in microsomes: < 14 mL.min-1.g-1
Compound 4 was reported as a limit; the forecaster's own chance of this, stated with the estimate: 5%; middle value at least 2.8-fold (0.45 log units) away from the limit.
By their numbers in this assay, from the lowest: compounds 3 and 2 (each within the scatter of the next); then compound 1. At a limit, below all of these: compound 4.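

In this assay, among these compounds, placing 1,2-dihydroxy-1-(trifluoromethyl)ethyl on the aromatic carbon para to a large group gives an at least 8.2-fold lower number from compound 1 to compound 4 (0.91 log units; beyond the scatter), the only single-place step so far. Compound 4 is reported as a limit of the assay, < 14 mL.min-1.g-1. The step therefore has a minimum size but no measured end: the limit of < 14 mL.min-1.g-1 in this assay, at which 1 of the 4 values shown sits.

The change removes the triple bond and adds a hydrogen-bond donor together, and the compounds shown do not separate the two. On these data alone, how a carboxylic acid or an amine at this position would read remains open.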